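Nitrophenyl amide in place of cyclohexyl amide

The source may hold more compounds than are shown below. What is called first, only, known or untested is meant among the compounds shown, and "the series" means these compounds.

The series shares a nitro-substituted anilide core carrying a benzyl-type ether. In an assay on SK-BR-3 cells for inhibition of Aromatase (Homo sapiens) (a higher number here means a weaker inhibitor, a lower number a stronger inhibitor), compound 1 `COc1ccc(COc2cc([N+](=O)[O-])ccc2N(C)S(C)(=O)=O)cc1` gives 470 nM and compound 2 `CN(c1ccc([N+](=O)[O-])cc1OCc1cccc2ccccc12)S(C)(=O)=O` gives 1170 nM; both carry a methylated methanesulfonamide nitrogen. Compound 3 `O=C(Nc1ccc([N+](=O)[O-])cc1OCc1ccccc1)C1CCCCC1` replaces the sulfonamide with a cyclohexanecarboxamide, and in this assay compound 3 gives > 25000 nM, which is a limit of the assay and not a number. Compound 3 therefore stands at the limit of > 25000 nM in this assay, at which 1 of the 3 values shown sits, with no numeric value of its own to compare against compound 1 or compound 2.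

Compound 4 `O=C(Nc1ccc([N+](=O)[O-])cc1OCc1ccccc1)c1ccc([N+](=O)[O-])cc1` is the next step: 4-nitrophenyl in place of cyclohexyl on a carbonyl carbon. Among the measured compounds shown here, no measured pair follows a comparable exchange on the carbonyl, so the size of the step has no precedent here. The expectation is that the amide type of compound 3 carries over, and that the step from compound 3 to compound 4 is an at least 1.2-fold lower number from compound 3 to compound 4 (0.09 log units; that floor lies within the scatter), within or near the scatter. Compound 4 is estimated at 20000 nM, expected to fall between 4000 nM and 60000 nM.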

Compound 4, half-maximal inhibitory concentration: > 25000 nM
Compound 4: only a limit was reported; the forecaster's own chance of this, stated with the estimate: 50%; middle value at least 1.2-fold (0.09 log units) away from the limit.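

Compound 3 and compound 4 each give only a limit and not a number in this assay, so no step between them can be read: the limit of > 25000 nM in this assay, at which 2 of the 4 values shown sit.

The compounds shown leave open whether 4-nitrophenyl and cyclohexyl on a carbonyl carbon differ at all.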